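The compounds below may be only part of what the source reports. "The series", "measured", "known", "first", "only" and "open" are said of these compounds alone.

Measured so far:
compound 1, `CN(C)c1ccc(/C=C(/SCc2ccc(Cl)cc2Cl)C(=O)c2ccc(Cl)cc2)cc1`: 50000 nM
compound 2, `O=C(/C(=C\c1csc([N+](=O)[O-])c1)S(=O)(=O)c1ccc(Br)cc1)c1ccc(Br)cc1`: 1000 nM

Within the data shown here, in a functional assay on DU-145 cells (Homo sapiens) for inhibition, read by trypan blue exclusion, with a stated time of 96 h (on this read-out higher numbers stand for weaker inhibition of growth and lower numbers for stronger inhibition of growth), compound 2 gives the lower of the two numbers; the nearest is compound 1, whose value stands well beyond the scatter above it, but the two differ in many places and no single step between them is available. Compound 3, `COc1ccc(/C=C(\C(=O)c2ccc(Br)cc2)S(=O)(=O)c2ccc(Br)cc2)cc1`, is not yet measured. It differs from compound 2 thus: 4-methoxyphenyl in place of 5-nitrothiophen-3-yl on a double-bonded chain carbon bound to a double-bonded chain carbon. Among the measured compounds shown here, with only this change and no comparable step to lean on, a moderate move toward weaker growth inhibition is expected, a 5.0-fold higher number from compound 2 to compound 3 (0.70 log units; beyond the scatter). Compound 3 is therefore estimated at 5000 nM, within 1000 nM to 25000 nM.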

Compound 3, concentration for 50% growth inhibition: 25000 nM
The estimate for compound 3 lay 5.0-fold (0.70 log units) below the measured number; low and high end bracket the measured number.
By their numbers in this assay, from the lowest: compound 2; then compounds 3 and 1 (each within the scatter of the next).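

In this assay, among these compounds, this is the first single change that can be read. At the place on a double-bonded chain carbon bound to a double-bonded chain carbon, 4-methoxyphenyl in place of 5-nitrothiophen-3-yl gives a 25-fold higher number from compound 2 to compound 3 (1.40 log units; beyond the scatter), so growth inhibition depends strongly on this group. The two groups have equal heavy-atom counts, so that count alone does not track the step.

As far as these compounds go, whether an unsubstituted phenyl or a 4-aminophenyl at this place would fall nearer compound 2 or compound 3 remains open. No measurement at hand accounts for the step.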